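The source may hold more compounds than are shown below. What is called first, only, known or untested is meant among the compounds shown, and "the series" means these compounds.

In an ADME assay (liver) for metabolic stability, with Liver microsome (Homo sapiens) as the target, read by LC-MS, using microsomes, tested at 1 uM (a lower number here means that the compound disappears faster, a higher number that the compound lasts longer), compound 1 `CCN(CC)CCCCCN/C(C)=N\c1ccnc2cc(Cl)ccc12` gives 0.933 h. Compound 2 `C/C(=N/c1ccnc2cc(Cl)ccc12)NCCCCN1CCCCC1` reports > 1 h, which is a limit of the assay and not a number. Compound 3 `C/C(=N/c1ccnc2cc(Cl)ccc12)NCCCN1CCCCC1` likewise stands only at a limit, > 1 h. Compound 4 `CCN(CC)CCN/C(C)=N\c1ccnc2cc(Cl)ccc12` carries diethylamino in place of (piperidin-1-yl)methyl on a saturated chain carbon, two bonds along the chain from an amine nitrogen. The measured steps that bear on this change are an at least 1.0-fold higher number from compound 1 to compound 2 (0.03 log units; that floor lies within the scatter) and an at least 1.0-fold higher number from compound 1 to compound 3 (0.03 log units; that floor lies within the scatter), while a step that the two limits leave unreadable from compound 2 to compound 3 cannot be sized. The readings stop at the limit of > 1 h in this assay, at which 2 of the 3 values shown sit. No step beyond the scatter is therefore expected in this assay. The expected change is a number no higher from compound 3 to compound 4 (the limit leaves the size open), an estimate that stays within the scatter. For compound 4 the expected half-life is 1 h, with an estimated range of 0.6 h to 1.6 h.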

Compound 4, half-life: 0.433 h
The estimate for compound 4 lay 2.3-fold (0.36 log units) above the measured number; the whole stated range lies above it.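

In this assay, within the data shown here, the earlier steps stayed within the scatter, but this change gives a step beyond it: diethylamino in place of 3-(diethylamino)propyl brings a 2.2-fold lower number from compound 1 to compound 4 (0.33 log units; beyond the scatter). Against the two piperidin-1-yl compounds, the change brings an at least 2.3-fold lower number from compound 3 to compound 4 (0.36 log units; beyond the scatter) and an at least 2.3-fold lower number from compound 2 to compound 4 (0.36 log units; beyond the scatter). These two steps are floors and not full sizes: the limit of > 1 h in this assay, at which 2 of the 4 values shown sit.

As far as these compounds go, whether the lower number goes with the shorter chain or with diethylamino replacing the piperidine ring stays open. From the compounds shown here alone, how a morpholin-4-yl group would read at this place also stays open.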